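Swapping Fluoro for Acetamido on a Shared Core

The source may report more compounds than this note shows. Statements on the series, on what has been measured and on what is new or still open speak of the compounds shown alone.

Of the compounds shown here, three built on one core have been measured in an ADME assay on BHK cells (Mesocricetus auratus) for cytotoxicity, read by MTT assay, with a stated time of 96 h; on this read-out higher numbers stand for lower toxicity in this test and lower numbers for higher toxicity in this test. Compound 1 `Fc1ccc(-c2nc3cc(C(F)(F)F)ccc3[nH]2)cc1` gives 25000 nM, compound 2 `O=C(CN1CCCCC1)Nc1ccc(-c2nc3cc(Cl)c(Cl)cc3[nH]2)cc1` gives 39000 nM, and compound 3 `COc1ccc(-c2nc3cc(Cl)c(Cl)cc3[nH]2)cc1` gives 18000 nM. Compound 1 holds the second highest of these three numbers, yet both compound 3 and compound 2 lie within the usual scatter of it, so no order among the three can be claimed. Compound 4 `CC(=O)Nc1ccc(-c2nc3cc(C(F)(F)F)ccc3[nH]2)cc1` has not yet been measured. It differs from compound 1 in one way: acetamido in place of fluoro on an aromatic carbon. Within the data shown here, no measured pair shows this change, so its size is unknown. Since compound 2 and compound 3 stay within scatter of compound 1, the expected step is a 1.1-fold higher number from compound 1 to compound 4 (0.05 log units; within the scatter). Compound 4 is therefore estimated at 28000 nM, with a range from 12000 nM to 65000 nM.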

Compound 4, half-maximal cytotoxic concentration: 53000 nM
Compound 4: middle estimate off by 1.9-fold (0.28 log units), on the low side; the measured number falls inside the stated range.
By their numbers in this assay, from the lowest: compounds 3, 1, 2 and 4 (each within the scatter of the next, the first and the last beyond it).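

Acetamido in place of fluoro on an aromatic carbon, para to a large group, gives a 2.1-fold higher number from compound 1 to compound 4 (0.33 log units; beyond the scatter) in this assay, so this is the first step on the shared core to lie beyond the scatter. This position therefore responds to the change, with the higher number standing for lower toxicity in this test, though the step is modest. Nothing available accounts for the step.

Going by these compounds, whether an amine or a carboxylic acid on this aromatic carbon would shift the number remains open. So does whether a longer chain in place of acetamido would extend the step.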